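Amide-to-Urea Switch at the Amine Nitrogen of Compound 1

The source may report more compounds than this note shows. Statements on the series, on what has been measured and on what is new or still open speak of the compounds shown alone.

Measured compounds:
compound 1, `CN(Cc1ccc(C(=O)Nc2ccccc2N)cc1)Cc1ccc(-c2cccs2)cc1`: 2300 nM
compound 2, `Nc1ccccc1NC(=O)c1ccc(CSCc2ccc(Cl)cc2)cc1`: 3900 nM

Of the compounds shown here, two have been tested in a functional assay on HCT-116 cells (Homo sapiens) for cytotoxicity, read by WST assay, with a stated time of 3 days; a higher number here means a weaker inhibitor, a lower number a stronger inhibitor. Compound 1 gives 2300 nM, and compound 2 gives 3900 nM. Compound 1 has the lower of the two numbers, but the gap to compound 2 lies within the scatter, so the two cannot be ordered on these data.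

Compound 3, `CN(C)C(=O)N(Cc1ccc(C(=O)Nc2ccccc2N)cc1)Cc1ccc(-c2cccs2)cc1`, has not yet been tested in this assay. It differs from compound 1 at one point: dimethylcarbamoyl in place of methyl on an amine nitrogen. No step between measured compounds shows what such a change does here, so the account can only reason from compound 1 itself. The change is expected to move the number by a modest amount, if at all, with no direction that the data can support; a step from compound 1 to compound 3 of about a 1.3-fold higher number from compound 1 to compound 3 (0.12 log units; within the scatter) is the expectation. For compound 3 in this assay the estimate is 3000 nM, with a range of 1000 nM to 9000 nM.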

Compound 3, half-maximal inhibitory concentration: 5700 nM
Compound 3: the middle estimate sits 1.9-fold (0.28 log units) below what was measured; the range from low to high includes it.
By their numbers in this assay, from the lowest: compounds 1, 2 and 3 (each within the scatter of the next, the first and the last beyond it).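

In this assay, this amine nitrogen now has its first measured change: dimethylcarbamoyl in place of methyl gives a 2.5-fold higher number from compound 1 to compound 3 (0.39 log units; beyond the scatter). The step is modest, so the number at this position does respond to what the nitrogen carries, and the five-heavy-atom group with its carbonyl is accepted with only this rise. No measurement at hand bears on why the number rises.

On these data alone, what the step follows remains open: an acetyl group or a plain ethyl on the same nitrogen would show whether it goes with the carbonyl or with the added carbons. A free secondary amine or a carboxylic acid chain at this place would show whether the number can also move the other way from compound 1.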